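The source may hold more compounds than are shown below. What is called first, only, known or untested is meant among the compounds shown, and "the series" means these compounds.

In an ADME assay on BHK-21 cells (Mesocricetus auratus) for cytotoxicity, with a stated time of 3 days (a lower number here means that less compound is tolerated, a higher number that more compound is tolerated), compound 1 (`CC(Sc1nnc(-c2ccncc2)s1)C(=O)Nc1ccccc1`) gives only the limit > 50000 nM and not a number. Compound 2 (`CC(Sc1nnc(-c2ccncc2)s1)C(=O)NCc1ccccc1`) likewise gives only the limit > 50000 nM in this assay. The step from compound 1 to compound 2, a step that the two limits leave unreadable from compound 1 to compound 2, therefore cannot be sized, which is what the limit of > 50000 nM in this assay, at which 2 of the 2 values shown sit, records: every value seen so far in this assay sits at that limit.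

Compound 3 (`CC(Sc1nnc(-c2ccncc2)s1)C(=O)Nc1c(Cl)cccc1Cl`) differs from compound 2 in one place: 2,6-dichlorophenyl in place of benzyl on an amide-type nitrogen. For the measured compounds named here, the only measured step bears on the same amide-type nitrogen, but both of its ends are limits, so it says nothing about the size or direction of a change at this position. Going by the values given here, no measured step thus supports an expectation of a shift beyond the scatter in this assay.

The expected step from compound 2 to compound 3 is accordingly a step that the limit leaves unreadable from compound 2 to compound 3. For compound 3 the estimated half-maximal cytotoxic concentration is 60000 nM, with a range from 20000 nM to 200000 nM, and a limit rather than a number is the more likely report.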

Compound 3, half-maximal cytotoxic concentration: > 50000 nM
Compound 3: a limit, no number; the forecaster's own chance of this, stated with the estimate: 70%; the middle value is on the limit's open side.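

Compound 3 gives only a limit in this assay, > 50000 nM, and not a number. No step among compound 1, compound 2 and compound 3 can therefore be read: the limit of > 50000 nM in this assay, at which 3 of the 3 values shown sit.

The compounds shown leave open whether phenyl, benzyl and 2,6-dichlorophenyl on the amide-type nitrogen differ at all in this assay.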